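The source may hold more compounds than are shown below. What is called first, only, known or untested is meant among the compounds shown, and "the series" means these compounds.

Compound 1 `CC(C)(N)C(=O)N[C@H](COCc1cccc(Cl)c1)c1nnnn1CCOC(=O)NCCCCO` is the starting point of this comparison. Within the data shown here, in a functional assay on cells for inhibition of growth hormone secretagogue receptor type 1 (Homo sapiens), read by FLIPR and calcium flux (a higher number here means that more compound is needed for the effect, a lower number that less compound is needed), compound 1 gives 1.6 nM, the highest of the two numbers measured so far. Among the measured compounds shown here, its only measured neighbour is compound 2 `Cc1ccccc1COC[C@@H](NC(=O)C(C)(C)N)c1nnnn1CCOC(=O)NCCCCO`, which in this assay gives 0.51 nM; the step of a 3.1-fold lower number from compound 1 to compound 2 (0.50 log units; beyond the scatter) shows that exchanging the group on the chain carbon shifts the number by a modest but real amount. Compound 3 `CC(C)(N)C(=O)N[C@H](COCC1CCCCC1)c1nnnn1CCOC(=O)NCCCCO` has not yet been measured. It differs from compound 1 as follows: cyclohexyl in place of 3-chlorophenyl on a saturated chain carbon bound to an oxygen on a saturated carbon. For the measured compounds named here, no measured step exchanges the aromatic ring itself for a saturated ring; the step from compound 1 to compound 2 only replaces one aromatic ring by another at the same place, so it bears on the new change only loosely, indicating that this place accepts variation without large swings. A step of a 2.0-fold higher number from compound 1 to compound 3 (0.30 log units; within the scatter) is therefore expected, with a somewhat weaker result judged more likely than a stronger one, while staying near the range already seen. The estimate for compound 3 in this assay is 3.2 nM, with a range from 0.8 nM to 13 nM.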

Compound 3, half-maximal effective concentration: 1.66 nM
Estimate against measurement, compound 3: 1.9-fold (0.29 log units) above; measured number inside the range.
By their numbers in this assay, from the lowest: compound 2; then compounds 1 and 3 (each within the scatter of the next).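

In this assay, the step of a 1.0-fold higher number from compound 1 to compound 3 (0.02 log units; within the scatter) shows that the aromatic 3-chlorophenyl can give way to the non-aromatic cyclohexyl, a ring without chlorine, on a saturated chain carbon bound to an oxygen on a saturated carbon, with no difference that the measurement can separate. Among these compounds, then, an aromatic ring at this place is not needed to keep the number where compound 1 has it, and neither is the chlorine. Aromaticity alone does not set the number, however. Both 3-chlorophenyl and 2-methylphenyl are aromatic and still differ, and the step of a 3.3-fold higher number from compound 2 to compound 3 (0.51 log units; beyond the scatter) shows that cyclohexyl does not share the lower number that 2-methylphenyl gives, leaving compound 2 lowest of the three, with steps to both others beyond the scatter.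

The compounds shown leave open how far this place tolerates other groups, such as a smaller cyclopentyl ring, an open butyl chain, or a cyclohexyl ring carrying an amine or a methyl group. Nothing available here explains why the numbers fall as they do.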